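This account rests on a few compounds, and the source may have more. Where it says the series, first, only, none or still open, it means among the compounds named here.

Of the compounds shown here, three sharing one core have been measured in a functional assay, tested at 100 ug/mL; on this read-out lower numbers stand for a stronger effect and higher numbers for a weaker effect at the one concentration tested. Compound 1 `COC(=O)C1=C(C)N(c2ccc(OC)cc2)C=C(C)C1c1ccccc1` gives -19.8%, compound 2 `COC(=O)C1=C(C)N(c2ccccc2)C=C(C)C1c1ccccc1` gives -21.1%, and compound 3 `COC(=O)C1=C(C)N(c2cccc(Cl)c2)C=C(C)C1c1ccccc1` gives -21.3%. Compound 3 has the lowest of the three numbers, yet each step among them, a number 1.3 percentage points lower from compound 1 to compound 2 (within the scatter), a number 1.5 percentage points lower from compound 1 to compound 3 (within the scatter) and a number 0.2 percentage points lower from compound 2 to compound 3 (within the scatter), lies within the scatter, so none of the three stands apart. Compound 4 `COC(=O)C1=C(C)N(c2cccc(C)c2C)C=C(C)C1c1ccccc1` differs from compound 3 in one place: 2,3-dimethylphenyl in place of 3-chlorophenyl on an amine nitrogen in a ring. The steps that change the group on an amine nitrogen in a ring, a number 1.5 percentage points lower from compound 1 to compound 3 (within the scatter) and a number 0.2 percentage points lower from compound 2 to compound 3 (within the scatter), were both within the scatter, so no step beyond the scatter is expected in this assay. Compound 4 is therefore expected to give -20%, between -31% and -9%. This estimate amounts to an expected step of a number 1.3 percentage points higher from compound 3 to compound 4 (within the scatter), within the scatter.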

Compound 4, a percentage reported as activity, at one concentration (the size of the read-out at that concentration, not a potency): -23.6%
Compound 4: middle estimate off by 3.6 percentage points, on the high side; low and high end bracket the measured number.
By their numbers in this assay, from the lowest: compounds 4, 3, 2 and 1 (each within the scatter of the next).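

Within this assay the 2,3-dimethylphenyl group on the amine nitrogen in a ring gives a number 2.3 percentage points lower from compound 3 to compound 4 (within the scatter) and a number 2.5 percentage points lower from compound 2 to compound 4 (within the scatter) and a number 3.8 percentage points lower from compound 1 to compound 4 (within the scatter) and thus stays in the same narrow band as the other groups. Even with two methyl groups on the aromatic ring, this position shows no step beyond the scatter. No measurement here offers a reason for this flat picture. 

Going by these compounds, all four compounds keep a carbon aromatic ring on this nitrogen, so it remains open whether a simple alkyl chain, or a phenyl ring bearing a carboxylic acid or an amine, would move the number beyond the scatter. On these data alone, the methoxycarbonyl and phenyl groups stay the same throughout, so changes there remain open too.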